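A few compounds are considered here, and "the series" means these few. Any claim that something is new, unique, unknown or untested is made for them only; others in the source may bear on it.

Measured compounds:
compound 1 `CC(C)c1nc(C(=O)NCC2CCN(C3CCC3)CC2)c2ccccn12`: 9.8 nM
compound 2 `CCN1CCC(NC(=O)c2nc(C(C)C)n3ccccc23)CC1`: 50 nM

In a functional assay on CHO cells for agonist activity at 5-hydroxytryptamine receptor 4 (Homo sapiens), read by a luciferase reporter and cAMP accumulation, with a stated time of 4 h (on this read-out lower numbers stand for an effect already at smaller amounts and higher numbers for an effect only at larger amounts of compound), compound 1 gives 9.8 nM and compound 2 gives 50 nM. Compound 2 thus stands with the highest number of the two measured compounds, and its gap to compound 1 lies beyond the scatter. Among the measured compounds shown here, the two differ from each other in more than one place, so no single step connects them and their values can only be set side by side.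

Compound 3 `CC(C)c1nc(C(=O)NC2CCN(CC3(O)CCOCC3)CC2)c2ccccn12` has not yet been measured. It keeps the shared core and the amide of compound 2 and is changed only at the group on the ring nitrogen: 4-hydroxyoxan-4-yl in place of methyl on a saturated chain carbon bound to an amine nitrogen in a ring. Compound 1, which carries a different group on that same ring nitrogen and a different link to the amide, gives 9.8 nM, which shows that this position tolerates variation without loss. The expected step, a 2.0-fold lower number from compound 2 to compound 3 (0.30 log units; within the scatter), is a modest move toward a lower number, or none beyond the scatter. Compound 3 is therefore estimated at 25 nM, within 6 nM to 100 nM.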

Compound 3, half-maximal effective concentration: 144 nM
Compound 3: middle estimate off by 5.8-fold (0.76 log units), on the low side; measured number outside the range, above it.
By their numbers in this assay, from the lowest: compound 1; then compound 2; then compound 3.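

In this assay, among the compounds shown here, replacing methyl with 4-hydroxyoxan-4-yl on a saturated chain carbon bound to an amine nitrogen in a ring gives a 2.9-fold higher number from compound 2 to compound 3 (0.46 log units; beyond the scatter), the first direct reading of a change at this position. It shows that this position does not accept every change without loss: here, a much larger group with a ring, a hydroxyl and a ring oxygen goes with a need for more compound to reach the half-maximal effect. The step is modest, though, and compound 3 still acts in the nanomolar range, so this large group weakens the effect without abolishing it, and nothing measured here explains why the number rises.

The new group brings its ring, its hydroxyl and its ring oxygen in a single change, so the compounds shown cannot tell which of these parts goes with the step. Comparing compound 2 with close relatives carrying a plain propyl chain, a cyclohexylmethyl group or an oxan-4-ylmethyl group without the hydroxyl would begin to separate the effects of chain length, the ring and the hydroxyl.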